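This account rests on a few compounds, and the source may have more. Where it says the series, first, only, none or still open, it means among the compounds named here.

Three sulfonamides built on one shared core were tested in an assay on cells for inhibition of HSP60/HSP10 (Homo sapiens), with a stated time of 60 min; a higher number here means a weaker inhibitor, a lower number a stronger inhibitor. Compound 1 `COc1ccc(S(=O)(=O)Nc2ccc(-c3nc4ccccc4o3)cc2)cc1` gave only a limit of the assay, > 100000 nM. Compound 2 `COc1ccc(Cl)cc1S(=O)(=O)Nc1ccc(-c2nc3ccccc3o2)cc1` likewise reached only a limit in this assay, > 100000 nM. Compound 3 `COc1ccccc1S(=O)(=O)Nc1ccc(-c2nc3ccccc3o2)cc1` also gave only a limit in this assay, > 100000 nM. Compound 3 thus stands where the other two stand, at the limit (the limit of > 100000 nM in this assay, at which 3 of the 3 values shown sit), and no number is known for any of the three. The steps between them cannot be sized for that reason: a step that the two limits leave unreadable from compound 1 to compound 2, a step that the two limits leave unreadable from compound 1 to compound 3 and a step that the two limits leave unreadable from compound 2 to compound 3.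

Compound 4 `CS(=O)(=O)Nc1ccc(-c2nc3ccccc3o2)cc1` has not yet been measured. It differs from compound 3 in one place: methyl in place of 2-methoxyphenyl on a sulfonyl sulfur. The 2-methoxyphenyl leaves the sulfonyl sulfur and a methyl enters there. The three measured steps, none readable, are all that bears on this change, and they offer no direction. The expected step in this assay is a step that the limit leaves unreadable from compound 3 to compound 4, essentially none beyond the scatter. Compound 4 is estimated at 150000 nM, within a range from 50000 nM to 500000 nM, and most likely again reported only as a limit.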

Compound 4, half-maximal inhibitory concentration: > 100000 nM
Compound 4: a limit, no number; the forecaster's own chance of this, stated with the estimate: 85%; the middle value does not contradict the limit.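

Compound 4 also gives only a limit, > 100000 nM. Its steps from compound 1, compound 2 and compound 3 therefore cannot be read: the limit of > 100000 nM in this assay, at which 4 of the 4 values shown sit. The compounds shown leave open whether any group on the sulfonyl sulfur of this shared core gives a measurable number in this assay.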